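The source may report more compounds than this note shows. Statements on the series, on what has been measured and on what is new or still open speak of the compounds shown alone.

Compound 3 `O=C(O)c1cc(-n2cnnc2)ccc1O` sits at the edge of what a functional assay on the whole organism for inhibition, with Rattus norvegicus as the target, read by paw edema (on this read-out lower numbers stand for an effect already at smaller amounts and higher numbers for an effect only at larger amounts of compound), can report: in this assay compound 3 gives > 250 mg/kg, a limit rather than a number. Compound 1 `O=C(O)c1cc(C2N=NN=N2)ccc1O` gives 110 mg/kg in this assay, and compound 2 `O=C(O)c1cc(-n2ccnn2)ccc1O` gives 150 mg/kg. Compound 4 `O=C(O)c1cc(-n2cccn2)ccc1O` carries 1H-pyrazol-1-yl in place of 4H-1,2,4-triazol-4-yl on an aromatic carbon. The measured swaps of this five-membered ring bear on it: an at least 2.2-fold higher number from compound 1 to compound 3 (0.35 log units; beyond the scatter), an at least 1.6-fold higher number from compound 2 to compound 3 (0.22 log units; that floor lies within the scatter), and a 1.4-fold higher number from compound 1 to compound 2 (0.13 log units; within the scatter). Because the limit of > 250 mg/kg in this assay, at which 1 of the 3 values shown sits, leaves compound 3 with only a floor, the size of any step from it is uncertain. The step of an at least 1.3-fold lower number from compound 3 to compound 4 (0.14 log units; that floor lies within the scatter) is expected to bring compound 4 back toward the numbers of compound 1 and compound 2. Compound 4 is therefore estimated at 180 mg/kg, with a range from 90 mg/kg to 400 mg/kg.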

Compound 4, dose for half-maximal effect: 200 mg/kg
Compound 4: the middle estimate sits 1.1-fold (0.05 log units) below what was measured, within the range that was stated.
By their numbers in this assay, from the lowest: compounds 1, 2 and 4 (each within the scatter of the next). At a limit, above all of these: compound 3.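

In this assay the 1H-pyrazol-1-yl group, on the aromatic carbon meta to a carboxy group and para to a hydroxy group, reads no differently from the two rings nearest to it: the change gives a 1.3-fold higher number from compound 2 to compound 4 (0.12 log units; within the scatter) and a 1.8-fold higher number from compound 1 to compound 4 (0.26 log units; within the scatter). The 1H-pyrazol-1-yl group therefore stays within the scatter of compound 1 and compound 2 at this position. Against the limit of compound 3 the change gives only an at least 1.2-fold lower number from compound 3 to compound 4 (0.09 log units; that floor lies within the scatter) and its true size stays unknown: the limit of > 250 mg/kg in this assay, at which 1 of the 4 values shown sits.

From the compounds shown here alone, whether this position needs a ring at all stays open. So does what an amine or a longer chain would give in its place.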